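Carbamoyl to carboxy in a small series

A few compounds are considered here, and "the series" means these few. Any claim that something is new, unique, unknown or untested is made for them only; others in the source may bear on it.

Measured so far in a functional assay on HCT-116 cells (Homo sapiens) for antiproliferative activity, read by sulforhodamine B assay, with a stated time of 72 h; a higher number here means a weaker inhibitor, a lower number a stronger inhibitor:
- compound 1 `Cn1ncc(Cl)c1-c1cc(C(=O)N[C@@H]2CN[C@H](CCn3cncn3)C[C@H]2c2ccc(Cl)c(Cl)c2)oc1Cl` gives 560 nM
- compound 2 `Cn1ncc(Cl)c1-c1cc(C(=O)N[C@@H]2CN[C@H](CCN3CCCCC3)C[C@H]2c2ccc(Cl)c(Cl)c2)oc1Cl` gives 1020 nM
- compound 3 `Cn1ncc(Cl)c1-c1cc(C(=O)N[C@@H]2CN[C@H](CC(N)=O)C[C@H]2c2ccc(Cl)c(Cl)c2)oc1Cl` gives 650 nM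

Compound 3 does not stand apart from the other two. Its nearest neighbour is given by the step of a 1.2-fold higher number from compound 1 to compound 3 (0.06 log units; within the scatter) and its furthest by the step of a 1.6-fold lower number from compound 2 to compound 3 (0.20 log units; within the scatter) while the remaining pair shows a 1.8-fold higher number from compound 1 to compound 2 (0.26 log units; within the scatter) as its step, so the three values sit together.

The change to compound 4 `Cn1ncc(Cl)c1-c1cc(C(=O)N[C@@H]2CN[C@H](CC(=O)O)C[C@H]2c2ccc(Cl)c(Cl)c2)oc1Cl` is hydroxy in place of amino on a carbonyl carbon and turns carbamoyl into carboxy. Among the compounds with values here, no measured compound carries a carboxy group, so no step shows this change directly. The closest guides are the exchanges a 1.2-fold higher number from compound 1 to compound 3 (0.06 log units; within the scatter) and a 1.6-fold lower number from compound 2 to compound 3 (0.20 log units; within the scatter) on the same chain, and neither goes beyond the scatter. On that evidence, no step beyond the scatter is expected in this assay for this change. The estimated step is a 1.4-fold higher number from compound 3 to compound 4 (0.14 log units; within the scatter) and its direction is held only weakly. The range is kept wide, given the lack of any measured carboxy precedent. Compound 4 is estimated at 900 nM with 350 nM to 2800 nM as the expected range.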

Compound 4, half-maximal inhibitory concentration: 4020 nM
The estimate for compound 4 lay 4.5-fold (0.65 log units) below the measured number; measured number outside the range, above it.
By their numbers in this assay, from the lowest: compounds 1, 3 and 2 (each within the scatter of the next); then compound 4.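

In this assay, within the data shown here, the chain at this position had so far carried 1H-1,2,4-triazol-1-yl, piperidin-1-yl and carbamoyl end groups with no step beyond the scatter, and the carboxy group is the first to give one, with a 6.2-fold higher number from compound 3 to compound 4 (0.79 log units; beyond the scatter). The shift is not tied to the carbamoyl comparison alone, as a 3.9-fold higher number from compound 2 to compound 4 (0.60 log units; beyond the scatter) and a 7.2-fold higher number from compound 1 to compound 4 (0.86 log units; beyond the scatter) run the same way and leave compound 4 as the weakest of the four in this assay. The position is therefore not indifferent to its substituent: the exchange of hydroxy for amino on a carbonyl carbon moves the number beyond the scatter, which none of the wider exchanges among compound 1, compound 2 and compound 3 did.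

Going by these compounds, whether the step belongs to the free carboxylic acid or to this chain length stays open, and a methyl ester of compound 4 or a carboxylic acid on a longer chain would separate those two readings. Nothing in the data shown accounts for the size of the step, so the result stands as an observation in this one cell assay.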